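A few compounds are considered here, and "the series" means these few. Any claim that something is new, unique, unknown or untested is made for them only; others in the source may bear on it.

Compound 1 `CC(NC(=O)/C=C/c1ccc(NC(=O)Nc2ccc(Cl)c(C(F)(F)F)c2)cc1)c1ccccc1`: 12200 nM
Compound 2 `CNC(=O)/C(C)=C/c1ccc(NC(=O)Nc2ccc(Cl)c(C(F)(F)F)c2)cc1`: 44300 nM
Compound 3 `CC(NC(=O)/C=C/Oc1ccc(NC(=O)Nc2ccc(Cl)c(C(F)(F)F)c2)cc1)c1ccccc1`: 14100 nM

In a functional assay on HepG2 cells (Homo sapiens) for inhibition, read by MTT assay, with a stated time of 120 h (a lower number here means a stronger inhibitor, a higher number a weaker inhibitor), compound 2 gives the highest of the three numbers, 44300 nM, and its gaps to compound 1 and compound 3 both lie beyond the usual scatter. Compound 4 `CNC(=O)C#Cc1ccc(NC(=O)Nc2ccc(Cl)c(C(F)(F)F)c2)cc1` is the next step from compound 2: 2-(methylcarbamoyl)ethynyl in place of 2-(methylcarbamoyl)prop-1-en-1-yl on an aromatic carbon. In words, 2-(methylcarbamoyl)ethynyl stands in place of 2-(methylcarbamoyl)prop-1-en-1-yl on an aromatic carbon. For the measured compounds named here, no measured pair isolates a single change, so the data give no direct size for this step. A modest step toward a lower number is expected in this assay, possibly none beyond the scatter, as compound 2 at 44300 nM is the top of the three. The expected change is a 1.5-fold lower number from compound 2 to compound 4 (0.17 log units; within the scatter). The estimated value for compound 4 is 30000 nM, with an expected range of 12000 nM to 70000 nM.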

Compound 4, half-maximal inhibitory concentration: 23300 nM
Compound 4: the middle estimate sits 1.3-fold (0.11 log units) above what was measured; low and high end bracket the measured number.
By their numbers in this assay, from the lowest: compounds 1, 3, 4 and 2 (each within the scatter of the next, the first and the last beyond it).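

In this assay, 2-(methylcarbamoyl)ethynyl in place of 2-(methylcarbamoyl)prop-1-en-1-yl, on an aromatic carbon para to a large group, gives a 1.9-fold lower number from compound 2 to compound 4 (0.28 log units; within the scatter), a step within the scatter. For the compounds shown here, this is the first single-place comparison, and at this position the two groups cannot be told apart. No measured data explain the size of this step. Open: whether a carboxylic acid or a longer chain in place of the methylcarbamoyl end, on the ethynyl group, would move the number beyond the scatter.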